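The source may hold more compounds than are shown below. What is called first, only, known or untested is meant among the compounds shown, and "the series" means these compounds.

Measured so far:
compound 1, `COc1cc2c(=O)c(C(=O)c3ccc(C)cc3)cn(Cc3ccc(N)cc3)c2cc1OC`: "not active" (no number reported)
compound 2, `COc1cc2c(=O)c(C(=O)c3ccc(C)cc3)cn(Cc3ccc(C(C)C)cc3)c2cc1OC`: 15500 nM

For the measured compounds named here, in an ADME assay on Huh-7 cells (Homo sapiens) for cytotoxicity (on this read-out lower numbers stand for stronger inhibition of growth and higher numbers for weaker inhibition of growth), compound 2 gives 15500 nM, the only number reported. In this assay compound 1 is reported as "not active" (no number reported), without a number. Compound 3 is `COc1cc2c(=O)c(C(=O)c3ccc(C)cc3)cn(Cc3ccc(Cl)cc3)c2cc1OC`; it differs from compound 2 by chloro in place of isopropyl on an aromatic carbon. Going by the values given here, no step between two measured compounds is available to size this change, so only a modest step is expected, if any, toward a higher number. Compound 3 is estimated at 25000 nM, between 8000 nM and 80000 nM, which means an expected step of a 1.6-fold higher number from compound 2 to compound 3 (0.21 log units; within the scatter).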

Compound 3, concentration for 50% growth inhibition: 15500 nM
Estimate against measurement, compound 3: 1.6-fold (0.21 log units) above; the range from low to high includes it.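

In this assay the swap of isopropyl for chloro on this aromatic carbon shows no change at the digits printed from compound 2 to compound 3 (within the scatter) even though three carbon atoms leave and a single chlorine atom enters. For this one pair, the size of the group at this place does not show up in the read-out. Nothing measured here explains why the two groups read alike.

Steps involving compound 1 cannot be read, as it carries no number. As far as these compounds go, whether a carboxylic acid or a longer chain such as butyl would also leave the read-out in place stays open.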